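A few compounds are considered here, and "the series" means these few. Any claim that something is new, unique, unknown or untested is made for them only; others in the source may bear on it.

- Compound 1 `O=C1c2c[n+]([O-])c3ccccc3c2C(=O)c2c1c1ccccc1n2Cc1cn([C@@H]2C[C@H](O)[C@@H](CO)O2)nn1`: 150 nM
- Compound 2 `CCCCN1CCN(CCCCn2c3c(c4ccccc42)C(=O)c2c[n+]([O-])c4ccccc4c2C3=O)CC1`: 6100 nM

In a functional assay on SH-SY5Y cells (Homo sapiens) for cytotoxicity, read by MTT assay, with a stated time of 72 h (a higher number here means a weaker inhibitor, a lower number a stronger inhibitor), compound 1 gives 150 nM, the lower of the two numbers, and its gap to compound 2 lies beyond the scatter. Compound 3 `O=C1c2c[n+]([O-])c3ccccc3c2C(=O)c2c1c1ccccc1n2Cc1cn([C@H]2C[C@H](O)[C@@H](CO)O2)nn1` has not yet been measured. Its change from compound 1 is purely one of spatial arrangement: the two compounds have the same atoms and bonds and differ only in configuration as drawn: 1 of 3 stereo elements differ; a stereocentre at a saturated ring carbon is drawn S in compound 1 and R in compound 3. Within the data shown here, no measured pair shows what such a change does, so the expectation is uncertain, but the expected result is no step beyond the scatter. The estimated change is a 1.3-fold higher number from compound 1 to compound 3 (0.12 log units; within the scatter). For compound 3, the expected value is 200 nM, with an estimated range of 70 nM to 600 nM.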

Compound 3, half-maximal inhibitory concentration in the SH-SY5Y assay: 620 nM
Estimate against measurement, compound 3: 3.1-fold (0.49 log units) below, and the stated range ends below it.
By their numbers in the SH-SY5Y assay, from the lowest: compound 1; then compound 3; then compound 2.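

In the SH-SY5Y assay, inverting one stereocentre at a saturated ring carbon, drawn S in compound 1 and R in compound 3, gives a 4.1-fold higher number from compound 1 to compound 3 (0.62 log units; beyond the scatter). Among these compounds, with atoms and bonds unchanged, configuration at this carbon alone therefore moves the number beyond the scatter, something the earlier compounds could not show. In a physicochemical assay for solubility, read by HPLC, with a stated time of 24 h (on this read-out higher numbers stand for higher solubility and lower numbers for lower solubility), compound 1 gives > 5000 ug/mL as a limit and not a number. In the physicochemical assay compound 3 gives > 5000 ug/mL as a limit and not a number. In the physicochemical assay, the step between these two compounds cannot be read, as each value is a limit and not a number: the limit of > 5000 ug/mL in the physicochemical assay, at which 2 of the 2 values shown sit.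

The compounds shown leave open what changing the other stereo elements would do. As far as these compounds go, it also remains open whether this step would persist with an amine in place of the ring hydroxyl.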